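Furoyl Amide Replaces Fluorobenzoyl on a Shared Core

The source may report more compounds than this note shows. Statements on the series, on what has been measured and on what is new or still open speak of the compounds shown alone.

Compound 1 `O=C(CCc1ccccc1)Nc1ccc(N2CCN(c3ccc(OC[C@@H]4CO[C@@](Cn5cncn5)(c5ccc(Cl)cc5Cl)O4)cc3)CC2)cc1` and compound 2 `O=C(Nc1ccc(N2CCN(c3ccc(OC[C@@H]4CO[C@@](Cn5cncn5)(c5ccc(Cl)cc5Cl)O4)cc3)CC2)cc1)c1cccc(F)c1` share a common core and differ only in the group on the amide carbonyl. In a functional assay on A549 cells (Homo sapiens) for inhibition, read by MTT assay, with a stated time of 48 h (on this read-out higher numbers stand for weaker inhibition and lower numbers for stronger inhibition), compound 1 gives 2060 nM, while compound 2 gives 6640 nM. Among the measured compounds shown here, the change is a 3.2-fold higher number from compound 1 to compound 2 (0.51 log units; beyond the scatter), so compound 2 has the higher of the two numbers, with compound 1 as its only neighbour. Compound 3 `O=C(Nc1ccc(N2CCN(c3ccc(OC[C@@H]4CO[C@@](Cn5cncn5)(c5ccc(Cl)cc5Cl)O4)cc3)CC2)cc1)c1ccco1` is not yet measured; it carries furan-2-yl in place of 3-fluorophenyl on a carbonyl carbon. For the measured compounds named here, the only measured step touches the same carbonyl position but swaps a phenethyl for an aromatic ring, a different kind of change, so it offers limited guidance. An aryl-to-heteroaryl swap of this size is expected to move the number little; the estimated step is a 1.2-fold lower number from compound 2 to compound 3 (0.08 log units; within the scatter). Compound 3 is therefore estimated at 5500 nM, within a range from 2200 nM to 14000 nM.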

Compound 3, half-maximal inhibitory concentration: 10500 nM
For compound 3 the middle estimate is 1.9-fold (0.28 log units) below the measured one; the range from low to high includes it.
By their numbers in this assay, from the lowest: compound 1; then compounds 2 and 3 (each within the scatter of the next).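

In this assay the swap to furan-2-yl on the carbonyl carbon gives a 1.6-fold higher number from compound 2 to compound 3 (0.20 log units; within the scatter), so this position does not separate the two aromatic rings, although the entering ring is smaller by the count of heavy atoms and brings a hydrogen-bond acceptor. The second new step, a 5.1-fold higher number from compound 1 to compound 3 (0.71 log units; beyond the scatter), joins the earlier one in placing phenethyl apart from both rings, and compound 1 stands as the strongest of the three, with neither other compound going against this. No supporting data are available to account for these differences.

On these data alone, what a benzyl or a 3-phenylpropyl group would give on the same carbonyl carbon remains open. So does whether a thiophen-2-yl or pyridin-3-yl ring would read like furan-2-yl and 3-fluorophenyl.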